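Swapping pentafluorosulfanyl for trifluoromethyl on the shared core

The compounds below may be only part of what the source reports. "The series", "measured", "known", "first", "only" and "open" are said of these compounds alone.

Measured so far in a functional assay on LNCaP cells (Homo sapiens) for antiproliferative activity, read by fluorescence and propidium iodide staining, with a stated time of 96 h; a higher number here means a weaker inhibitor, a lower number a stronger inhibitor:
compound 1 `O=C(Nc1ccc(S(F)(F)(F)(F)F)cc1)c1ccc(Sc2ccc(O)cc2)cc1` gives 4860 nM
compound 2 `O=C(Nc1cccc(S(F)(F)(F)(F)F)c1)c1ccc(Sc2ccc(O)cc2)cc1` gives 3320 nM

Compound 1 has the highest number of the two, but compound 2 lies within the scatter of it, so no order between them is claimed. Compound 3 `O=C(Nc1ccc(C(F)(F)F)cc1)c1ccc(Sc2ccc(O)cc2)cc1` is not yet measured. Against compound 1 it carries a group of 4 heavy atoms (1 carbon, 3 fluorine; no ring) in place of a group of 6 heavy atoms (5 fluorine, 1 sulfur; no ring), on an aromatic carbon, a group of 4 heavy atoms (1 carbon, 3 fluorine; no ring) in place of a group of 6 heavy atoms (5 fluorine, 1 sulfur; no ring), on an aromatic carbon. Among the measured compounds shown here, no measured pair shows this exchange, so nothing fixes its size; the expectation in this assay is no step beyond the scatter, in either direction. Compound 3 is estimated at 4500 nM, with a range from 1500 nM to 13000 nM. The expected step is a 1.1-fold lower number from compound 1 to compound 3 (0.03 log units; within the scatter).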

Compound 3, half-maximal inhibitory concentration: 8300 nM
The estimate for compound 3 lay 1.8-fold (0.27 log units) below the measured number, and the stated range covers the measured number.
By their numbers in this assay, from the lowest: compounds 2, 1 and 3 (each within the scatter of the next, the first and the last beyond it).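

In this assay, among the compounds shown here, the first single-place exchange, trifluoromethyl in place of pentafluorosulfanyl on an aromatic carbon para to a large group, gives a 1.7-fold higher number from compound 1 to compound 3 (0.23 log units; within the scatter) and so does not separate the two groups at this position. On this evidence, the position tolerates the smaller group with no step beyond the scatter, though that rests on one pair. No supporting measurement bears on this result.

Going by these compounds, whether an amine, a carboxylic acid or a nitrile at this position would give a step beyond the scatter stays open. So does the size of the same exchange on compound 2.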